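Methoxy in place of phenoxy on the pyridine arm

The compounds below may be only part of what the source reports. "The series", "measured", "known", "first", "only" and "open" are said of these compounds alone.

Of the compounds shown here, two of a shared bicyclic amine core have been tested in an in vitro functional assay on SH-EP1 cells for agonist activity at Neuronal acetylcholine receptor; alpha4/beta2 (Homo sapiens), read by FLIPR and calcium flux; on this read-out lower numbers stand for smaller maximal responses and higher numbers for larger maximal responses. Compound 1 `C1=C(c2cncnc2)CC2CNCC1C2` gives 116% there. Compound 2 `C1=C(c2cncc(Oc3ccccc3)c2)CC2CNCC1C2` gives 52% in this assay, the lowest of the two numbers, with compound 1 standing a gap beyond the usual scatter above it. Compound 3 `COc1cncc(C2=CC3CNCC(C2)C3)c1` has not been measured yet; it differs from compound 2 in one place: methyl in place of phenyl on an oxygen on an aromatic ring Cut one bond further out, the change reads phenoxy to methoxy. Among the compounds with values here, the numbers give no direct step for this kind of change, so the expectation rests only on the two values shown. Trimming the arm is expected to move the maximal response upward, by a moderate step beyond the scatter, toward the level of compound 1. In this assay compound 3 is expected to reach 85%, within a range from 55% to 115%. The step of a number 33 percentage points higher from compound 2 to compound 3 (beyond the scatter) is the estimated size of that change.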

Compound 3, largest response reached (reported as percent of maximum), in percent of the reference or control that the assay uses: 72%
Beside the measured number, compound 3's estimate is 13 percentage points above it, within the range that was stated.
By their numbers in this assay, from the lowest: compound 2; then compound 3; then compound 1.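

In this assay, keeping the oxygen on the aromatic ring and replacing its phenyl with methyl gives a modest rise, a number 20 percentage points higher from compound 2 to compound 3 (beyond the scatter). Within the data shown here, this is the first step in the set that changes only one place, and it shows that the maximal response depends on what this oxygen carries, since the step lies beyond the usual scatter. The data offer no evidence on what lies behind this shift.

A single step cannot separate the effect of losing the aromatic ring from that of simply having fewer atoms on the oxygen. From the compounds shown here alone, it remains open how the response would change with ethoxy or benzyloxy at this place, or with an amine or a hydroxyl group in place of the methoxy.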